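This account rests on a few compounds, and the source may have more. Where it says the series, first, only, none or still open, it means among the compounds named here.

Working notes on the series.

In an ADME assay on microsomes from liver (Homo sapiens) for metabolic stability, read by LC-MS, using NADPH, tested at 5 uM (a higher number here means that the compound lasts longer, a lower number that the compound disappears faster), compound 1 `NC(=O)c1cn(Cc2nnc(-c3cc(S(N)(=O)=O)c(SCc4ccccc4)cc3Cl)o2)nn1` gives 0.435 h and compound 2 `NCc1nnc(-c2cc(S(N)(=O)=O)c(SCc3ccccc3)cc2Cl)o1` gives 0.263 h. Within the data shown here, compound 2 thus holds the lower of the two numbers so far, but the step of a 1.7-fold lower number from compound 1 to compound 2 (0.22 log units; within the scatter) stays within the scatter, so the two compounds cannot be ordered on these data.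

Compound 3 `NS(=O)(=O)c1cc(-c2nnc(CNC(=O)c3ccccc3)o2)c(Cl)cc1SCc1ccccc1` is reached from compound 2 by benzoyl in place of hydrogen on an amine nitrogen, the amine passing from aminomethyl to benzamidomethyl. Among the measured compounds shown here, the only measured step that bears on this position is the replacement of the triazole carboxamide by the free amine, which gave a 1.7-fold lower number from compound 1 to compound 2 (0.22 log units; within the scatter); that change was without effect beyond the scatter, and nothing else at this position has been measured. A step of similar size is therefore expected here, a 1.3-fold higher number from compound 2 to compound 3 (0.12 log units; within the scatter), with no direction that the data can support. For compound 3 the half-life in this assay is estimated at 0.35 h, in the range 0.15 h to 0.8 h.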

Compound 3, half-life: 0.187 h
The estimate for compound 3 lay 1.9-fold (0.27 log units) above the measured number; low and high end bracket the measured number.
By their numbers in this assay, from the lowest: compounds 3, 2 and 1 (each within the scatter of the next, the first and the last beyond it).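

In this assay, benzoyl in place of hydrogen on the amine nitrogen gives a 1.4-fold lower number from compound 2 to compound 3 (0.15 log units; within the scatter), so aminomethyl and benzamidomethyl cannot be told apart on this read-out. The series does now hold its first step at this position beyond the scatter, though a modest one: benzamido in place of 4-carbamoyl-1H-1,2,3-triazol-1-yl on the saturated chain carbon gives a 2.3-fold lower number from compound 1 to compound 3 (0.37 log units; beyond the scatter), while compound 2 stays within the scatter of both. No measurement at hand offers an explanation for this difference.

As far as these compounds go, it remains open whether a smaller acyl group such as acetyl on the amine nitrogen, or a pyridine ring in place of the benzene ring of the benzoyl, would shift the half-life beyond the scatter. From the compounds shown here alone, a longer chain between the amide nitrogen and the shared core is equally open.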